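This account rests on a few compounds, and the source may have more. Where it says the series, first, only, none or still open, it means among the compounds named here.

Compound 1 `Nc1nc(NCc2ccccc2)c2ncn(/C=C3/CC3(CO)CO)c2n1` is one of three compounds tested in an ADME assay on Akata cells (Homo sapiens) for cytotoxicity, with a stated time of 7 days; a higher number here means that more compound is tolerated, a lower number that less compound is tolerated. In this assay compound 1 gives only a limit, > 24000 nM. Compound 2 `CCCCNc1nc(N)nc2c1ncn2/C=C1/CC1(CO)CO` likewise gives only a limit in this assay, > 24000 nM. Compound 3 `Nc1nc(OCC(F)(F)F)c2ncn(/C=C3/CC3(CO)CO)c2n1` also reaches only a limit in this assay, > 20000 nM. Since all three values are limits, the steps among them cannot be read: a step that the two limits leave unreadable from compound 1 to compound 2, a step that the two limits leave unreadable from compound 1 to compound 3 and a step that the two limits leave unreadable from compound 2 to compound 3. The values rest at the limit of > 24000 nM in this assay, at which 2 of the 3 values shown sit, and at the limit of > 20000 nM in this assay, at which 1 of the 3 values shown sits, so compound 1 stands with the others and cannot be placed higher or lower than either.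

Compound 4 `CCCCCCOc1nc(N)nc2c1ncn2/C=C1/CC1(CO)CO` differs from compound 1 in one place: hexyloxy in place of benzylamino on an aromatic carbon. Going by the values given here, the steps that bear on this change are the exchange of benzylamino for an alkoxy group, a step that the two limits leave unreadable from compound 1 to compound 3, and the exchange of an alkylamino group for an alkoxy group, a step that the two limits leave unreadable from compound 2 to compound 3; both are unreadable, and none of the three compounds gave a number below the limit. No step beyond the scatter is therefore expected in this assay; compound 4 is estimated to sit again at the limit, near 24000 nM, between 10000 nM and 60000 nM, which means an expected step of a number no higher from compound 1 to compound 4 (the limit leaves the size open).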

Compound 4, half-maximal cytotoxic concentration: > 20000 nM
Compound 4 was reported as a limit (the forecaster's own chance of this, stated with the estimate: 80%); the middle value lies beyond the limit too.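

In this assay compound 4 also gives only a limit, > 20000 nM, so its steps from compound 1, compound 2 and compound 3 cannot be read. The compounds shown leave open where the half-maximal cytotoxic concentration of any of these four compounds actually lies.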